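The compounds below may be only part of what the source reports. "The series", "measured", "known", "first", "only" and "open" are said of these compounds alone.

In a functional assay on A549 cells (Homo sapiens) for inhibition, read by CCK-8 assay, with a stated time of 48 h (on this read-out higher numbers stand for weaker inhibition and lower numbers for stronger inhibition), compound 1 `COc1cc(-c2ccnc3cc(-c4cccc(C#N)c4)nn23)cc(OC)c1OC` reports only a limit, > 10000 nM. Compound 2 `COc1cc(-c2ccnc3cc(-c4cccc(C)c4)nn23)cc(OC)c1OC` gives 5730 nM, and compound 3 `COc1ccc(-c2cc3nccc(-c4cc(OC)c(OC)c(OC)c4)n3n2)cc1F` gives 545 nM, the lowest number of the three. Compound 4 `COc1ccc(-c2cc3nccc(-c4cc(OC)c(OC)c(OC)c4)n3n2)cc1[N+](=O)[O-]` has nitro in place of fluoro on an aromatic carbon, ortho to a methoxy group (nitro in place of fluoro on an aromatic carbon). Within the data shown here, no measured step makes this swap alone. The nearest evidence is an at least 18-fold lower number from compound 1 to compound 3 (1.26 log units; beyond the scatter) and an 11-fold lower number from compound 2 to compound 3 (1.02 log units; beyond the scatter), both large and both replacing the whole aryl group, while an at least 1.7-fold lower number from compound 1 to compound 2 (0.24 log units; that floor lies within the scatter) stays within the scatter at its floor. Among the measured compounds shown here, compound 3 thus holds the only low number, so a moderate rise is expected, an estimated 2.8-fold higher number from compound 3 to compound 4 (0.44 log units; beyond the scatter). Compound 4 is estimated at 1500 nM, with an expected range of 300 nM to 7500 nM.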

Compound 4, half-maximal inhibitory concentration: > 10000 nM
Compound 4 was reported as a limit; the forecaster's own chance of this, stated with the estimate: 10%; middle value at least 6.6-fold (0.82 log units) away from the limit.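

Nitro in place of fluoro, ortho to a methoxy group, gives an at least 18-fold higher number from compound 3 to compound 4 (1.26 log units; beyond the scatter) in this assay. The earlier steps shown here each replaced a whole aryl group, whereas this one shows that changing a single group on that ring, with the methoxy group kept, is enough to lose the low number of compound 3. Compound 4 stands at a limit, so its step is only a floor: the limit of > 10000 nM in this assay, at which 2 of the 4 values shown sit.

The compounds shown leave open whether an amine or a hydroxyl group on this carbon would keep a number near that of compound 3. They also leave open how a plain hydrogen there would compare with fluoro.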